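From a Small Cyano Group to a Sulfonamide Arm

The source may report more compounds than this note shows. Statements on the series, on what has been measured and on what is new or still open speak of the compounds shown alone.

Three measured compounds share one core and differ only in the group on the amide-type nitrogen in the ring. Compound 1 `COc1ccc([C@H]2CC(=O)N(Cc3cccc(N)c3)C2)cc1OC1CCCC1` carries a 3-aminobenzyl group there, compound 2 `COc1ccc([C@H]2CC(=O)N(c3cccc(C#N)c3)C2)cc1OC1CCCC1` a 3-cyanophenyl group, and compound 3 `COc1ccc([C@H]2CC(=O)N(c3ccccn3)C2)cc1OC1CCCC1` a pyridin-2-yl group. In a functional assay on HEK293 cells (Homo sapiens) for cytotoxicity (a higher number here means that more compound is tolerated, a lower number that less compound is tolerated), compound 1 gives > 10000 nM, a limit of the assay rather than a number. Compound 2 gives > 10000 nM in this assay, again a limit. Compound 3 gives > 10000 nM in this assay, also a limit. Because all three sit at the limit of > 10000 nM in this assay, at which 3 of the 3 values shown sit, the steps a step that the two limits leave unreadable from compound 1 to compound 2, a step that the two limits leave unreadable from compound 1 to compound 3 and a step that the two limits leave unreadable from compound 2 to compound 3 cannot be sized, and compound 2 simply stands at the limit with the other two. Compound 4 `COc1ccc([C@H]2CC(=O)N(c3cccc(NS(=O)(=O)c4cccc(Br)c4)c3)C2)cc1OC1CCCC1` differs from compound 2 in that (((3-bromophenyl)sulfonyl)amino in place of cyano on an aromatic carbon). Among the measured compounds shown here, no measured step bears on this change in a readable way, so no step beyond the scatter is expected. For compound 4 the step this estimate means is expected to be a step that the limit leaves unreadable from compound 2 to compound 4. Compound 4 is expected to give about 12000 nM, within a range of 3000 nM to 40000 nM.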

Compound 4, half-maximal cytotoxic concentration: > 10000 nM
Compound 4: a limit, no number; the forecaster's own chance of this, stated with the estimate: 60%; the middle value is on the limit's open side.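

Compound 4 also gives a limit of the assay rather than a number, so the step between compound 2 and compound 4 cannot be read, because both sit at the same limit: the limit of > 10000 nM in this assay, at which 4 of the 4 values shown sit.

The compounds shown leave open whether ((3-bromophenyl)sulfonyl)amino in place of cyano changes the result in this assay at all.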